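Hexyl in Place of the Phenylethyl Group

The source may hold more compounds than are shown below. What is called first, only, known or untested is meant among the compounds shown, and "the series" means these compounds.

Measured in an assay on membranes from Sf9 cells for displacement of a labelled ligand from histamine H2 receptor (Homo sapiens), read by scintillation counting, with a stated time of 60 min; on this read-out lower numbers stand for stronger inhibition and higher numbers for weaker inhibition:
- compound 1, `Cc1nc(N)sc1CCCN/C(N)=N/C(=O)N[C@H](C)c1ccccc1`: 17.8 nM
- compound 2, `Cc1nc(N)sc1CCCN/C(N)=N/C(=O)NCC(C)CCc1ccccc1`: 63.1 nM
- compound 3, `Cc1nc(N)sc1CCCN/C(N)=N/C(=O)NC(c1ccccc1)c1ccccc1`: 43.7 nM

Among these three numbers compound 1 has the lowest, and its gaps to both compound 3 and compound 2 lie beyond the usual scatter, so within this small set it stands as the strongest binder in this assay. Compound 2 and compound 3 sit close to one another at the weaker end.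

Compound 4, `CCCCCCNC(=O)/N=C(\N)NCCCc1sc(N)nc1C`, has not yet been measured. It differs from compound 1 in one place: hexyl in place of 1-phenylethyl on an amide-type nitrogen. The ring that compound 1 carries, and that compound 2 and compound 3 also carry in their own ways, is therefore absent from compound 4. For the measured compounds named here, no pair in the measured set shows this exact change, so the size of the step can only be gauged from the spread of the three values.

The author expects the step from compound 1 to compound 4 in this assay to run toward weaker binding and to exceed the scatter, a 3.1-fold higher number from compound 1 to compound 4 (0.50 log units; beyond the scatter). Compound 4 is accordingly estimated at 56 nM, with a plausible range from 18 nM to 180 nM.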

Compound 4, inhibition constant: 28.8 nM
Beside the measured number, compound 4's estimate is 1.9-fold (0.29 log units) above it, and the stated range covers the measured number.
By their numbers in this assay, from the lowest: compounds 1, 4, 3 and 2 (each within the scatter of the next, the first and the last beyond it).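

In this assay, for the compounds shown here, putting hexyl in place of 1-phenylethyl on the amide-type nitrogen gives a 1.6-fold higher number from compound 1 to compound 4 (0.21 log units; within the scatter), the first direct reading of a single change at this position, and the step stays within the scatter. The six-membered aromatic ring and the defined stereocentre of 1-phenylethyl are therefore not required for binding in the range of this set, since compound 4, which has neither, gives 28.8 nM. No measurement offered here accounts for the two groups reading alike.

The compounds shown leave open how the value at this nitrogen follows chain length and shape, which a shorter chain such as butyl, a longer one such as octyl, or a cyclohexyl group would test against hexyl. They also leave open whether the aromatic ring and the stereocentre each count for anything on their own, a question that a plain benzyl group and the mirror-image form of 1-phenylethyl could separate.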